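A Methyl Added Far Out Along the Chain

The source may report more compounds than this note shows. Statements on the series, on what has been measured and on what is new or still open speak of the compounds shown alone.

Compound 1 `CCCCCCCCCCNC(=O)Nc1c(C)cccc1C(C)C`: 210 nM
Compound 2 `CCCCCCCCCCNC(=O)Nc1c(C)cccc1C(C)(C)C`: 200 nM
Compound 3 `CCCCCCCCCC(C)(C)CNC(=O)Nc1c(C(C)C)cccc1C(C)C`: 46 nM

Three ureas have been measured in an assay on microsomes from intestinal mucosa for inhibition of acyl-CoA:cholesterol acyltransferase (Oryctolagus cuniculus); on this read-out lower numbers stand for stronger inhibition and higher numbers for weaker inhibition. Compound 2 differs from compound 1 by methyl in place of hydrogen on a saturated chain carbon bound to an aromatic carbon and two saturated chain carbons, and that step gave a 1.1-fold lower number from compound 1 to compound 2 (0.02 log units; within the scatter). Compound 3 stands apart from both; how its core differs from that of compound 1 is not broken down here, but in this assay compound 3 gives the lowest number of the three, beyond the scatter from either.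

Compound 4 `CCCCCCCCCCC(C)(C)CNC(=O)Nc1c(C(C)C)cccc1C(C)C` has not yet been measured. It differs from compound 3 by methyl in place of hydrogen on a saturated chain carbon, ten or more bonds along the chain from an amide-type nitrogen, the same kind of change as between compound 1 and compound 2, though the place is not the same: there the carbon was bound to an aromatic carbon and two saturated chain carbons, here the carbon lies further out along the chain, as the difference just given states. Since the earlier step of a 1.1-fold lower number from compound 1 to compound 2 (0.02 log units; within the scatter) stayed within the scatter, a similarly small step is expected here, a 1.0-fold lower number from compound 3 to compound 4 (0.01 log units; within the scatter). Compound 4 is therefore estimated at 45 nM in this assay, with a likely range from 20 nM to 100 nM.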

Compound 4, half-maximal inhibitory concentration: 47 nM
The estimate for compound 4 lay 1.0-fold (0.02 log units) below the measured number; low and high end bracket the measured number.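

In this assay, methyl in place of hydrogen far out along the chain gave a 1.0-fold higher number from compound 3 to compound 4 (0.01 log units; within the scatter), a step the assay cannot separate from no change at all. Set beside the earlier step, the same change reads alike on the two cores: the same change on two cores in this assay, a 1.1-fold lower number (0.02 log units; within the scatter) from compound 1 to compound 2 and a 1.0-fold higher number (0.01 log units; within the scatter) from compound 3 to compound 4, 1.1-fold (0.03 log units) apart, within the scatter of two such steps This shows only that the change left the number unmoved at these two places on these two cores; the places differ, so it does not show that the same would hold at another carbon of the chain or on another core.

The compounds shown leave open what a hydroxyl, an amine or a carboxylic acid at the far end of the chain would do. They also leave open whether a still longer chain would keep the number where compound 4 has it.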